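A few compounds are considered here, and "the series" means these few. Any claim that something is new, unique, unknown or untested is made for them only; others in the source may bear on it.

Measured in a functional assay for inhibition of nuclear factor NF-kappa-B complex (Homo sapiens) (a higher number here means a weaker inhibitor, a lower number a stronger inhibitor), so far:
- compound 1 `COc1ccc2c(c1)OC(c1cc(OC)c(OC)c(OC)c1)C(C(=O)OC(C)C)=C2` gives 11800 nM
- compound 2 `COc1ccc2c(c1)OC(c1cc(OC)c(OC)c(OC)c1)C(C(=O)Nc1ccccc1)=C2` gives 17500 nM
- compound 3 `COc1ccc2c(c1)OC(c1cc(OC)c(OC)c(OC)c1)C(C(N)=O)=C2` reaches only the limit > 50000 nM

In this assay compound 2 holds the highest of the two numbers, but the step of a 1.5-fold higher number from compound 1 to compound 2 (0.17 log units; within the scatter) is within the scatter, so no order between compound 1 and compound 2 can be read. For compound 3 only the limit of > 50000 nM in this assay, at which 1 of the 3 values shown sits, stands.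

Compound 4 `COc1ccc2c(c1)OC(c1cc(OC)c(OC)c(OC)c1)C(C(C)=O)=C2` differs from compound 2 by methyl in place of anilino on a carbonyl carbon. Going by the values given here, two measured steps bear on this. The step of an at least 2.8-fold higher number from compound 2 to compound 3 (0.45 log units; beyond the scatter) removes the phenyl from the amide-type nitrogen and weakens inhibition. The step of an at least 4.2-fold higher number from compound 1 to compound 3 (0.62 log units; beyond the scatter) likewise pares the group on the carbonyl carbon down to its smallest form and weakens inhibition. Both trimmings of the carbonyl substituent cost potency, so a weakening step is expected here too, of roughly a 1.7-fold higher number from compound 2 to compound 4 (0.23 log units; within the scatter). Compound 4 is therefore estimated at 30000 nM in this assay, with a range of 12000 nM to 90000 nM, and a result reported only as a limit cannot be excluded.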

Compound 4, half-maximal inhibitory concentration: 14100 nM
The estimate for compound 4 lay 2.1-fold (0.33 log units) above the measured number, within the range that was stated.
By their numbers in this assay, from the lowest: compounds 1, 4 and 2 (each within the scatter of the next). At a limit, above all of these: compound 3.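

On the carbonyl carbon, methyl in place of anilino gives a 1.2-fold lower number from compound 2 to compound 4 (0.09 log units; within the scatter), and methyl in place of isopropoxy gives a 1.2-fold higher number from compound 1 to compound 4 (0.08 log units; within the scatter), so in this assay no order can be read among these three groups and the anilino ring is not required at this position. Amino is the group that stands apart here, with methyl in its place giving an at least 3.5-fold lower number from compound 3 to compound 4 (0.54 log units; beyond the scatter), so paring the carbonyl substituent down does not by itself go with the loss seen for compound 3. The value of compound 3 is a limit, not a number: the limit of > 50000 nM in this assay, at which 1 of the 4 values shown sits.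

Open, as far as these compounds go, is how dimethylamino, the hydroxyl of a carboxylic acid, or a chain longer than methyl would read on this carbonyl carbon. Also open, from the compounds shown here alone, is whether any group at this position gives a number clearly lower than that of compound 1 at 11800 nM.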